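A few compounds are considered here, and "the series" means these few. Any claim that something is new, unique, unknown or untested is made for them only; others in the source may bear on it.

Compound 2 has the structure `C=CC1=C(C(=O)NCc2ccc(Cl)cc2)C(c2ccc(OC)cc2)OC1` and compound 1 the structure `C=CC1=C(C(=O)NC(C)(C)C)C(c2ccc(OC)cc2)OC1`; they share one core and differ only in the group on the amide-type nitrogen. In a functional assay on QGY7701 cells (Homo sapiens) for cytotoxicity, read by MTT assay, with a stated time of 24 h (a lower number here means a stronger inhibitor, a higher number a weaker inhibitor), compound 1 reaches no number and is reported only as the limit > 100000 nM. In this assay compound 2 likewise reaches no number and is reported only as the limit > 100000 nM. The step that the two limits leave unreadable from compound 1 to compound 2 is therefore unreadable, since both ends of it sit at the limit of > 100000 nM in this assay, at which 2 of the 2 values shown sit. Where compound 2 stands on the numbers shown is thus fixed only as a limit, with no value of its own.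

Compound 3, with the structure `C=CC1=C(C(=O)NCC(C)C)C(c2ccc(OC)cc2)OC1`, is the next member of the series. It differs from compound 2 by isopropyl in place of 4-chlorophenyl on a saturated chain carbon bound to an amide-type nitrogen, the same difference read one bond further out being 4-chlorobenzyl to isobutyl. Only the unreadable step from compound 1 to compound 2 bears on this change, and it gives no size in either direction. Compound 3 is therefore expected to sit near the same limit, with the estimate 100000 nM between 30000 nM and 300000 nM. The expected step of a number no higher from compound 2 to compound 3 (the limit leaves the size open) is thus none beyond the scatter.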

Compound 3, half-maximal inhibitory concentration: > 100000 nM
Compound 3: a limit, no number (the forecaster's own chance of this, stated with the estimate: 80%); the middle value sits exactly at the limit.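

Compound 3 reaches no number in this assay and is reported only as the limit > 100000 nM. Going by these compounds alone, no step among compound 1, compound 2 and compound 3 can be read, as all of them rest on one limit: the limit of > 100000 nM in this assay, at which 3 of the 3 values shown sit. The compounds shown leave open how strongly any of these three would inhibit, and whether the group on the amide-type nitrogen matters at all.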